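Nitro to 4-Methylphenyl: Expected Cell Toxicity of Compound 4

This account rests on a few compounds, and the source may have more. Where it says the series, first, only, none or still open, it means among the compounds named here.

Measured so far in an ADME assay on HEK-293T cells (Homo sapiens) for cytotoxicity, read by MTT assay, tested at 100 uM; a higher number here means a weaker effect of the compound at the concentration tested, a lower number a stronger effect:
compound 1, `COc1ccc(O)c(C(=O)Nc2ncc([N+](=O)[O-])s2)c1`, gives 100%
compound 2, `CC(C)c1cc(C(=O)Nc2ncc([N+](=O)[O-])s2)c(O)c(C(C)C)c1`, gives 7.1%
compound 3, `O=C(Nc1ncc([N+](=O)[O-])s1)c1ccc([N+](=O)[O-])o1`, gives 67.3%

Compound 3 holds the second highest of the three numbers; compound 1 lies above it by a margin beyond the scatter, and compound 2 lies well below it, also beyond the scatter. Compound 4, `Cc1ccc(-c2ccc(C(=O)Nc3ncc([N+](=O)[O-])s3)o2)cc1`, is not yet measured in this assay. It differs from compound 3 in one place: 4-methylphenyl in place of nitro on an aromatic carbon. Going by the values given here, no step between two measured compounds is known here, so the size of this change can only be guessed. Among the compounds with values here, compound 2, the one with two isopropyl groups, gives 7.1%, the lowest number, so a moderate drop in this assay is expected for compound 4. The estimate for compound 4 is 45%, ranging from 15% to 80%. This means an expected step of a number 22.3 percentage points lower from compound 3 to compound 4 (beyond the scatter).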

Compound 4, a percentage reported as activity, at one concentration (the size of the read-out at that concentration, not a potency): 91.5%
Beside the measured number, compound 4's estimate is 46.5 percentage points below it, and the stated range ends below it.
By their numbers in this assay, from the lowest: compound 2; then compound 3; then compounds 4 and 1 (each within the scatter of the next).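

In this assay, putting 4-methylphenyl in place of nitro on this aromatic carbon next to the ring oxygen gives a number 24.2 percentage points higher from compound 3 to compound 4 (beyond the scatter) and so weakens the effect on the cells. At this position, then, removing nitro and adding a larger aromatic ring does not strengthen the effect at the concentration tested. No measurement shown here explains this shift. On these data alone, it remains open whether the change comes from losing nitro or from gaining the 4-methylphenyl ring. An amine or a carboxylic acid at this position would add further comparisons.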